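The source may report more compounds than this note shows. Statements on the series, on what has been measured and on what is new or still open speak of the compounds shown alone.

Compound 1, whose structure is `COc1ccc(-c2cnc3nc(N)nc(OC(C)C)c3n2)cc1`, carries an isopropoxy group on the shared core. In a functional assay on cells (T-cell, Homo sapiens) for inhibition (a higher number here means a weaker inhibitor, a lower number a stronger inhibitor), compound 1 gives > 10000 nM, which is a limit of the assay rather than a number. Compound 2, `CCOc1nc(N)nc2ncc(-c3ccc(CC)cc3)nc12`, has an ethoxy group in the same position, and in this assay compound 2 gives 8200 nM. Compound 3, `COc1ccc(-c2cnc3nc(N)nc(N4CCN(c5ccc(C)cc5)CC4)c3n2)cc1OC`, instead bears a piperazine ring that carries a 4-methylphenyl group, and in this assay compound 3 gives 300 nM, the lowest of the two numbers recorded; its gap to compound 2 lies beyond the usual scatter.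

Compound 4, `COc1ccc(-c2cnc3nc(N)nc(N4CCN(C(=O)Nc5ccccc5)CC4)c3n2)cc1OC`, differs from compound 3 in one place: phenylcarbamoyl in place of 4-methylphenyl on an amine nitrogen in a ring. No measured step of this kind is available among the compounds shown, so the effect of exchanging an aromatic group directly on the ring nitrogen for a phenylcarbamoyl group is uncertain. The step from compound 3 to compound 4 in this assay is expected to be a modest loss, a 2.7-fold higher number from compound 3 to compound 4 (0.43 log units; beyond the scatter). Compound 4 is therefore estimated at 800 nM, within a range from 150 nM to 5000 nM.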

Compound 4, half-maximal inhibitory concentration: 3.4 nM
For compound 4 the middle estimate is 240-fold (2.37 log units) above the measured one; the whole stated range lies above it.
By their numbers in this assay, from the lowest: compound 4; then compound 3; then compound 2. At a limit, above all of these: compound 1.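

On an amine nitrogen in a ring, the choice of group matters greatly in this assay: phenylcarbamoyl in place of 4-methylphenyl gives an 88-fold lower number from compound 3 to compound 4 (1.95 log units; beyond the scatter). Both groups contain one six-membered aromatic ring of carbon only, so that ring alone does not set the number; what the entering group adds is a carbonyl and an amide hydrogen, with one hydrogen-bond donor and one hydrogen-bond acceptor counted. Nothing measured here explains why this change has so large an effect.

No compound shown separates the contribution of the carbonyl from that of the amide hydrogen, so it remains open which part of phenylcarbamoyl goes with the gain. A benzoyl group on the same nitrogen, which keeps the carbonyl but lacks the amide hydrogen, would help to separate them.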